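Weak inhibitors of a human methionine tRNA ligase

The source may hold more compounds than are shown below. What is called first, only, known or untested is meant among the compounds shown, and "the series" means these compounds.

Compound 1 `O=C(O)c1cc(-c2ccc(-c3ccc(Cl)cc3Cl)cc2)n(-c2ccc(Cl)cc2Cl)n1` was tested in an assay on isolated protein for inhibition of methionine--tRNA ligase, cytoplasmic (Homo sapiens) (on this read-out lower numbers stand for stronger inhibition and higher numbers for weaker inhibition), and there compound 1 gives 11900 nM. Compound 2 `O=C(O)c1cc(-c2ccc(-c3ccc(Cl)cc3Cl)cc2)n(Cc2ccncc2)n1` differs from it only at the aromatic nitrogen of the shared core, and in this assay compound 2 gives 26200 nM. Among the measured compounds shown here, that single known step, a 2.2-fold higher number from compound 1 to compound 2 (0.34 log units; beyond the scatter), is the only measured comparison available, so compound 1 stands at the lowest of the two numbers, with compound 2 a little weaker. Compound 3 `O=C(O)c1cc(-c2ccc(-c3ccc(F)c(Cl)c3)cc2)n(-c2ccc(Cl)cc2Cl)n1` changes a different part of the molecule: 3-chloro-4-fluorophenyl in place of 2,4-dichlorophenyl on an aromatic carbon. For the measured compounds named here, no measured step touches this end of the structure, so there is nothing that directly foretells the result; the exchange swaps one halogenated ring for another of the same size, and the expected step, a 1.3-fold higher number from compound 1 to compound 3 (0.10 log units; within the scatter), is within the scatter. Compound 3 is therefore estimated to give 15000 nM in this assay, within a range from 5000 nM to 45000 nM.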

Compound 3, half-maximal inhibitory concentration: 20900 nM
Compound 3: middle estimate off by 1.4-fold (0.14 log units), on the low side; the range from low to high includes it.
By their numbers in this assay, from the lowest: compounds 1, 3 and 2 (each within the scatter of the next, the first and the last beyond it).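

The exchange of 2,4-dichlorophenyl for 3-chloro-4-fluorophenyl, on an aromatic carbon at the far end of the molecule, gives a 1.8-fold higher number from compound 1 to compound 3 (0.24 log units; within the scatter). Among the compounds shown here, this is the first look at this position, and it shows that one halogenated ring can stand in for the other with no difference that can be told apart from the ordinary spread of repeated measurements, at least for this one pair. No measured information is available to explain this result.

Going by these compounds, both rings at this position carry only halogens, so it remains open whether a plain phenyl or a ring bearing a methoxy group or an amine would shift the number. Also open, on these data alone, is how 3-chloro-4-fluorophenyl would behave with (pyridin-4-yl)methyl on the aromatic nitrogen of the shared core.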